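Replacing Methyl with 4-Cyanophenyl on the Carbonyl Carbon

The source may hold more compounds than are shown below. What is called first, only, known or untested is meant among the compounds shown, and "the series" means these compounds.

In a functional assay on MKN-45 cells (Homo sapiens) for cytotoxicity (a lower number here means a stronger inhibitor, a higher number a weaker inhibitor), compound 1 `COc1ccc(S(=O)(=O)N2CCc3cccc(NC(C)=O)c32)cc1` gives 61 nM. That lies within the scatter of compound 2 `COc1ccc(S(=O)(=O)N2CCc3cc(Br)cc(NC(=O)c4ccco4)c32)cc1` at 78 nM and of compound 3 `COc1ccc(S(=O)(=O)N2CCc3cc(Br)cc(NC(=O)c4ccncc4)c32)cc1` at 86 nM, so compound 1 has no clear edge over either.

Compound 4 `COc1ccc(S(=O)(=O)N2CCc3cccc(NC(=O)c4ccc(C#N)cc4)c32)cc1` keeps the core of compound 1 but has 4-cyanophenyl in place of methyl on a carbonyl carbon. Among the measured compounds shown here, the one measured step bearing on this is a 1.1-fold higher number from compound 2 to compound 3 (0.04 log units; within the scatter), where pyridin-4-yl replaces furan-2-yl on a carbonyl carbon. For the measured compounds named here, no measured step shows methyl being replaced, so the evidence is indirect.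

The expected change is small, an estimated 1.4-fold higher number from compound 1 to compound 4 (0.14 log units; within the scatter). For compound 4 the estimated value is 85 nM, with an expected range of 35 nM to 210 nM.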

Compound 4, half-maximal inhibitory concentration: 89 nM
Compound 4: middle estimate off by 1.0-fold (0.02 log units), on the low side; low and high end bracket the measured number.
By their numbers in this assay, from the lowest: compounds 1, 2, 3 and 4 (each within the scatter of the next).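

In this assay, putting 4-cyanophenyl in place of methyl on the carbonyl carbon gives a 1.5-fold higher number from compound 1 to compound 4 (0.16 log units; within the scatter). Among the compounds shown here, the earlier compounds compared only one ring with another at this carbonyl, whereas this direct step shows that a small methyl and a much larger aryl group give numbers within the scatter of each other on the shared core. No evidence at hand bears on this result.

On these data alone, it remains open whether an amine or a carboxylic acid in place of the nitrile, or a longer alkyl chain in place of methyl, would shift the number beyond the scatter.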